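The compounds below may be only part of what the source reports. "The series", "measured", "known", "first", "only" and "open" are said of these compounds alone.

Measured so far in a functional assay on BGC-823 cells (Homo sapiens) for cytotoxicity, read by MTT assay; on this read-out higher numbers stand for weaker inhibition and lower numbers for stronger inhibition:
Compound 1 `Cc1ccccc1Nc1nc(C)c(C(=O)/C=C/c2ccc(Cl)cc2)s1` gives > 25000 nM, a limit of the assay.
Compound 2 `Cc1ccccc1Nc1nc(C)c(C(=O)/C=C/c2ccccc2)s1` gives > 25000 nM, likewise a limit of the assay.
Compound 3 `Cc1cccc(Nc2nc(C)c(C(=O)/C=C/c3ccccc3)s2)c1` gives 13600 nM.

Compound 1 thus stands at the upper edge of what this assay reports; only a limit is known for it, and it shares that position with compound 2 (the limit of > 25000 nM in this assay, at which 2 of the 3 values shown sit). Going by the values given here, the one readable number in the set belongs to compound 3.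

The change under consideration is 3,4-dichlorophenyl in place of 2-methylphenyl on a nitrogen on an aromatic ring, giving compound 4 `Cc1nc(Nc2ccc(Cl)c(Cl)c2)sc1C(=O)/C=C/c1ccc(Cl)cc1`. Among the compounds with values here, two measured steps touch the series. The step that the two limits leave unreadable from compound 1 to compound 2 concerns the chloro on the aromatic carbon of the cinnamoyl side, not the aryl on the ring nitrogen, and both ends sit at the limit, so it carries no readable size. The step of an at least 1.8-fold lower number from compound 2 to compound 3 (0.26 log units; that floor lies within the scatter) is the only one at the nitrogen-bound aryl; it moves a methyl from 2-methylphenyl to 3-methylphenyl and shows a floor that lies within the scatter. Within the data shown here, no measured step exchanges methyl for chloro on that aryl, and none adds a second substituent there.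

On this basis the expected change from compound 1 to compound 4 is an at least 1.3-fold lower number from compound 1 to compound 4 (0.14 log units; that floor lies within the scatter), with no direction established beyond the scatter and a fair chance that compound 4 again returns only a limit. Compound 4 is estimated at 18000 nM, in the range 6000 nM to 50000 nM.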

Compound 4, half-maximal inhibitory concentration: 22700 nM
Beside the measured number, compound 4's estimate is 1.3-fold (0.10 log units) below it; the range from low to high includes it.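

Going by these compounds alone, compound 4 is the first compound in the set with a chloro on the cinnamoyl side to return a readable number in this assay, and that number comes with 3,4-dichlorophenyl in place of 2-methylphenyl on the nitrogen, at 22700 nM. Compound 1 remains a limit of the assay, and its position is shared with compound 2: the limit of > 25000 nM in this assay, at which 2 of the 4 values shown sit. The new comparison therefore yields only an at least 1.1-fold lower number from compound 1 to compound 4 (0.04 log units; that floor lies within the scatter), so this change at the nitrogen-bound aryl has a floor but no established direction, and a dichlorinated aryl there is not shown to differ from the 2-methylphenyl of compound 1.

Compound 3 and compound 4 differ in two places, so they give no clean reading of 3-methylphenyl against 3,4-dichlorophenyl, and the step between compound 1 and compound 2 cannot be read, which leaves the effect of the chloro on the cinnamoyl side unresolved. Also open, as far as these compounds go, is how this assay would respond to a single chloro on that aryl, or to a methoxy group, a dimethylamino group or a carboxylic acid there.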